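This account rests on a few compounds, and the source may have more. Where it says the series, first, only, none or still open, it means among the compounds named here.

Measured compounds:
- compound 1, `CCN1C(=O)S/C(=C\c2ccc(N)cc2)C1=O`: 76000 nM in a functional assay on FM3A cells (Mus musculus) for cytotoxicity, read by cell counting, with a stated time of 2 days; a lower number here means a stronger inhibitor, a higher number a weaker inhibitor
- compound 2, `C=C(Br)C(=O)Nc1ccc(/C=C2\SC(=O)N(C)C2=O)cc1`: 750 nM in this assay

Compound 2 stands lowest of the two numbers shown; its nearest neighbour is compound 1, which gives a far higher number, a gap well beyond the scatter. Going by the values given here, the two share the same core, and compound 1 also carries an ethyl rather than a methyl on the ring nitrogen of the core, so no single step between them is counted.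

The next compound, compound 3, `CN1C(=O)S/C(=C\c2ccc(N)cc2)C1=O`, is not yet measured. Its difference from compound 2 is hydrogen in place of (1-bromoethenyl)carbonyl on a nitrogen on an aromatic ring. The remaining part of compound 3 is a free amino group on the aromatic ring, as in compound 1.

Expectation for the step: compound 1, which bears hydrogen on the same nitrogen, gives 76000 nM, so compound 3 is expected to move toward that number, and the step from compound 2 to compound 3 is estimated as a large rise, an 80-fold higher number from compound 2 to compound 3 (1.90 log units; beyond the scatter), far beyond the scatter. For compound 3 the estimate in this assay is 60000 nM, with a range from 20000 nM to 200000 nM.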

Compound 3, half-maximal inhibitory concentration: 107000 nM
Beside the measured number, compound 3's estimate is 1.8-fold (0.25 log units) below it, within the range that was stated.
By their numbers in this assay, from the lowest: compound 2; then compounds 1 and 3 (each within the scatter of the next).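

In this assay the loss of (1-bromoethenyl)carbonyl from the nitrogen on the aromatic ring can now be read as a single change, with a 140-fold higher number from compound 2 to compound 3 (2.15 log units; beyond the scatter) as its size, so the large gap between compound 2 and the amines no longer has to be shared with the chain on the ring nitrogen of the core. That chain change, hydrogen in place of methyl on a saturated chain carbon bound to an amide-type nitrogen in a ring, gives a 1.4-fold higher number from compound 1 to compound 3 (0.15 log units; within the scatter) and so separates compound 1 and compound 3 by no more than repeated measurements would, with the free amino group present in both. No measurement here bears on why the acylated nitrogen gives the lower number.

Which part of the (1-bromoethenyl)carbonyl group carries the step remains open, and a plain acetyl or an unbrominated propenoyl on the same nitrogen would begin to separate the bromine and the double bond from the amide carbonyl. Going by these compounds, it is also open whether the flat response to the ethyl and methyl chains holds when the nitrogen on the aromatic ring is acylated, or for a longer chain such as butyl on the ring nitrogen.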